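Trimethoxyphenyl for an ester arm on the pyrimidine amine

The source may report more compounds than this note shows. Statements on the series, on what has been measured and on what is new or still open speak of the compounds shown alone.

This account follows compound 2, `CCOC(=O)CNc1ncc([N+](=O)[O-])c(N(CC(=O)OCC)Cc2ccccc2)n1`, and its closely related companion compound 1, `CCOC(=O)CN(Cc1ccccc1)c1nc(NCc2ccccc2)ncc1[N+](=O)[O-]`. In a functional assay on MCF7 cells (Homo sapiens) for antiproliferative activity, read by MTT assay, with a stated time of 48 h (on this read-out higher numbers stand for weaker inhibition and lower numbers for stronger inhibition), compound 1 gives only a limit of the assay, > 100000 nM. In this assay compound 2 likewise gives only a limit, > 100000 nM. For the measured compounds named here, the single step between them, a step that the two limits leave unreadable from compound 1 to compound 2, therefore offers no readable size. Compound 2 thus stands at the limit shared by both measured compounds, (the limit of > 100000 nM in this assay, at which 2 of the 2 values shown sit).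

The unmeasured compound 3, `CCOC(=O)CN(Cc1ccccc1)c1nc(Nc2cc(OC)c(OC)c(OC)c2)ncc1[N+](=O)[O-]`, differs from compound 2 by 3,4,5-trimethoxyphenyl in place of (ethoxycarbonyl)methyl on a nitrogen on an aromatic ring. Going by the values given here, no measured step bears on this change, and the two limits give no direction; the prose can only expect that a numerical value, if one appears, could lie anywhere from well below the limit up to the limit itself.

The estimate for compound 3 in this assay is 40000 nM (3000 nM to 100000 nM), which as a step means an at least 2.5-fold lower number from compound 2 to compound 3 (0.39 log units; beyond the scatter).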

Compound 3, half-maximal inhibitory concentration: > 100000 nM
Compound 3 gave a limit, no number; the forecaster's own chance of this, stated with the estimate: 55%; middle value at least 2.5-fold (0.39 log units) away from the limit.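

In this assay compound 3 gives only a limit of the assay, > 100000 nM, so the steps to it from compound 1 and compound 2 cannot be read. The compounds shown leave open which change on the shared core, if any, would bring a numerical value in this assay.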